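The source may report more compounds than this note shows. Statements on the series, on what has been measured and on what is new or still open speak of the compounds shown alone.

Measured so far:
Compound 1 `CC1=C(C(=O)O[C@@H](C)CO[N+](=O)[O-])[C@H](c2cccc3nonc23)C([N+](=O)[O-])=C(C)C1` gives 9430 nM in a functional assay (ileum) for antagonist activity, with Cavia porcellus as the target; a lower number here means a stronger inhibitor, a higher number a weaker inhibitor.
Compound 2 `CC1=C(C(=O)OCCO[N+](=O)[O-])[C@@H](c2cccc3nonc23)C([N+](=O)[O-])=C(C)C1` gives 115 nM in this assay.
Compound 3 `CC1=C(C(=O)OCCCCO[N+](=O)[O-])C(c2cccc3nonc23)C([N+](=O)[O-])=C(C)C1` gives 878 nM in this assay.

Among these three, compound 2 has the lowest number in this assay, and its distance to the nearest of the others, compound 3, is beyond the scatter, as is its larger distance to compound 1. The unmeasured compound 4 `CC1=C(C(=O)OCCO[N+](=O)[O-])[C@H](c2cccc3nonc23)C([N+](=O)[O-])=C(C)C1` is set against compound 2 as its closest relative. the two compounds have the same atoms and bonds and differ only in configuration as drawn: 1 of 1 stereo elements differ; a stereocentre at a saturated ring carbon is drawn R in compound 2 and S in compound 4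

Among the measured compounds shown here, no pair of measured compounds differs in one place alone, so the size of a step from one configuration to the other has not been observed directly. For the measured compounds named here, the only hint is compound 1, which is drawn with the same configuration as compound 4 at that stereocentre but differs from compound 2 in a second place as well; in this assay compound 1 gives 9430 nM, far above compound 2. The expectation is therefore a large step to a higher number, a 22-fold higher number from compound 2 to compound 4 (1.34 log units; beyond the scatter), with wide uncertainty because compound 1 does not isolate the configuration on its own. Compound 4 is estimated at 2500 nM, within a range of 400 nM to 15000 nM.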

Compound 4, half-maximal inhibitory concentration: 22400 nM
Beside the measured number, compound 4's estimate is 9.0-fold (0.95 log units) below it, outside the stated range (above it).
By their numbers in this assay, from the lowest: compound 2; then compound 3; then compound 1; then compound 4.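

Seen directly for the first time, the stereocentre at the saturated ring carbon carries a 190-fold higher number from compound 2 to compound 4 (2.29 log units; beyond the scatter) in this assay with no atom or bond changed, and the form drawn R is the stronger inhibitor of this pair. Against this, hydrogen in place of methyl on the saturated chain carbon, with the ring stereocentre drawn S in both compounds, gives only a 2.4-fold higher number from compound 1 to compound 4 (0.38 log units; beyond the scatter) and so moves the number far less, although that step is still beyond the scatter. The large step can be assigned to configuration alone because of one fact: the fact that compounds 2 and 4 differ only in the configuration as drawn.

As far as these compounds go, the steps involving compound 3 cannot be read, since it is drawn without a configuration at the ring carbon and also carries a longer chain, so it remains open how much of its 878 nM belongs to the chain and whether the preference for the form drawn R holds there or with the methyl-bearing chain of compound 1. Also open, from the compounds shown here alone, is whether that preference would survive if a carboxylic acid or an amine took the place of the nitrate ester at the end of the chain.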